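Removing the aryl group from a weak cytotoxic series

The compounds below may be only part of what the source reports. "The series", "measured", "known", "first", "only" and "open" are said of these compounds alone.

Of the compounds shown here, three sharing one core have been measured in a functional assay on NB-4 cells (Homo sapiens) for cytotoxicity, read by CCK-8 assay, with a stated time of 24 h; a higher number here means a weaker inhibitor, a lower number a stronger inhibitor. Compound 1 `C=CC(=O)N1C(=O)CC(c2ccc(C)cc2)Sc2ccccc21` gives 37300 nM. Compound 2 `C=CC(=O)N1C(=O)CC(c2ccc(OC)cc2)Sc2ccccc21` gives 32900 nM, and compound 3 `C=CC(=O)N1C(=O)CC(c2ccc(Br)cc2)Sc2ccccc21` gives 59400 nM. The three numbers sit close together: the step of a 1.1-fold lower number from compound 1 to compound 2 (0.05 log units; within the scatter) is within the scatter, as are a 1.6-fold higher number from compound 1 to compound 3 (0.20 log units; within the scatter) and a 1.8-fold higher number from compound 2 to compound 3 (0.26 log units; within the scatter). Compound 3 therefore stands no apart from its two neighbours; exchanging methyl, methoxy or bromo on the aromatic carbon has not moved this assay beyond its noise.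

Compound 4 `C=CC(=O)N1C(=O)CCSc2ccccc21` takes a different route. The change hydrogen in place of 4-bromophenyl on a saturated ring carbon is not a swap of one substituent for another but the loss of the whole aromatic ring. None of the three measured steps describes such a loss; each of them kept the ring and only changed one group on it, and all three stayed within the scatter. There is thus no measured guide to the size of this step, only the observation that the series as a whole is weak. The expectation is that compound 4 will be weaker still or at best comparable, with an estimated step of a 1.5-fold higher number from compound 3 to compound 4 (0.18 log units; within the scatter). Compound 4 is estimated at 90000 nM, between 35000 nM and 230000 nM.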

Compound 4, half-maximal inhibitory concentration: 22400 nM
Compound 4: the middle estimate sits 4.0-fold (0.60 log units) above what was measured, outside the stated range (below it).
By their numbers in this assay, from the lowest: compounds 4, 2, 1 and 3 (each within the scatter of the next, the first and the last beyond it).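

In this assay, taking the aryl group off the saturated ring carbon next to the ring sulfur does not cost cytotoxicity: loss of 4-bromophenyl gives a 2.7-fold lower number from compound 3 to compound 4 (0.42 log units; beyond the scatter), the only one of these removals beyond the scatter, while loss of 4-methoxyphenyl gives a 1.5-fold lower number from compound 2 to compound 4 (0.17 log units; within the scatter) and loss of 4-methylphenyl gives a 1.7-fold lower number from compound 1 to compound 4 (0.22 log units; within the scatter). The earlier compounds shown here only exchanged a group on the aromatic ring and so could not show whether the ring itself was needed; compound 4 shows that at this position the series keeps its reading in this assay with hydrogen alone, so the aromatic ring is dispensable here. Nothing available accounts for this result, and the numbers record only the size of the steps.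

The compounds shown leave open whether a different group on this carbon, such as an amine, a carboxylic acid or a short alkyl chain, would move the number beyond the scatter in either direction. They also leave open how much the vinylcarbonyl group contributes, since every compound here carries it, and a saturated propanoyl group in its place would test that.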